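A few compounds are considered here, and "the series" means these few. Any claim that something is new, unique, unknown or untested is made for them only; others in the source may bear on it.

Measured compounds:
compound 1 `O=C(CCCCCn1cc(Nc2ncc(Cl)c(Nc3cccc(Cl)c3)n2)cn1)NO`: 580 nM
compound 2 `CNc1nc(Nc2cnn(CCCCCCC(=O)NO)c2)ncc1Cl`: 590 nM
compound 3 `O=C(CCCCCn1cc(Nc2ncc(Cl)c(Nc3ccccc3Cl)n2)cn1)NO`: 1810 nM

All three were tested in a functional assay on K562 cells (Homo sapiens) for antiproliferative activity, read by MTT assay, with a stated time of 48 h; a lower number here means a stronger inhibitor, a higher number a weaker inhibitor. Compound 2 stands second highest of the three numbers; its nearest neighbour is compound 1, whose value lies within the scatter of its own, while compound 3 sits beyond the scatter, at a higher number. Compound 4 `O=C(CCCCCCn1cc(Nc2ncc(Cl)c(Nc3ccc(F)cc3)n2)cn1)NO` differs from compound 2 in one place: 4-fluorophenyl in place of methyl on a nitrogen on an aromatic ring. Within the data shown here, only one measured step bears on this change, a 3.1-fold higher number from compound 1 to compound 3 (0.49 log units; beyond the scatter), which concerns moving a chlorine around the phenyl ring rather than swapping methyl for phenyl. The values of compound 1 and compound 2 show that a 3-chlorophenyl group on that nitrogen gives much the same number as methyl. A 4-fluorophenyl group is therefore expected to behave similarly, with no step beyond the scatter, a 1.0-fold higher number from compound 2 to compound 4 (0.01 log units; within the scatter). Compound 4 is estimated at 600 nM, within a range of 250 nM to 1500 nM.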

Compound 4, half-maximal inhibitory concentration: 500 nM
The estimate for compound 4 lay 1.2-fold (0.08 log units) above the measured number; the measured number falls inside the stated range.
By their numbers in this assay, from the lowest: compounds 4, 1 and 2 (each within the scatter of the next); then compound 3.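

In this assay, replacing the methyl on this nitrogen with 4-fluorophenyl gives a 1.2-fold lower number from compound 2 to compound 4 (0.07 log units; within the scatter), so a single small carbon group and a whole aromatic ring can sit here with no change beyond the scatter. Among these compounds, the one earlier step only moved a chlorine around a phenyl ring, so this is the first direct comparison of an alkyl group with an aryl group at this place on an otherwise identical compound. Nothing measured here explains why the number holds steady across this change.

The compounds shown leave open whether a benzyl group, a morpholine ring or a phenyl ring bearing a carboxylic acid on this nitrogen would also leave the number in place. Among the compounds shown here, they also leave open how 4-fluorophenyl would fare with a longer chain than the one in compound 4.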